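Bromo for hydrogen on the fused ring of compound 2

The source may hold more compounds than are shown below. What is called first, only, known or untested is meant among the compounds shown, and "the series" means these compounds.

Measured compounds:
compound 1 `COc1ccc(C2=NN(C3=NC(=O)/C(=C4\C(=O)Nc5ccc(Br)cc54)S3)C(c3ccc(OC)cc3)C2)cc1` — 480 nM
compound 2 `COc1ccc(C2=NN(C3=NC(=O)/C(=C4\C(=O)Nc5ccccc54)S3)C(c3ccc(Cl)cc3)C2)cc1` — 100000 nM

In a functional assay on cells (Cancer cell lines, Homo sapiens) for cytotoxicity, read by sulforhodamine B assay, with a stated time of 48 h (on this read-out lower numbers stand for stronger inhibition of growth and higher numbers for weaker inhibition of growth), compound 1 gives 480 nM. In this assay compound 2 gives 100000 nM, the highest of the two numbers; compound 1 sits at a far lower number, a gap beyond the scatter. Compounds 1 and 2 differ in two places at once, so their values alone do not show which of the two changes carries that gap.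

Compound 3 `COc1ccc(C2=NN(C3=NC(=O)/C(=C4\C(=O)Nc5ccc(Br)cc54)S3)C(c3ccc(Cl)cc3)C2)cc1` has not yet been measured in this assay. Relative to compound 2 the change is bromo in place of hydrogen on an aromatic carbon. Compound 3 thereby shares the bromo of compound 1 and the chloro of compound 2, so it sits between the two measured compounds in structure. Within the data shown here, with no single-change step recorded, the size of the effect is open; a move toward lower numbers is expected, though the chloro that compound 3 keeps from compound 2 may hold part of the high value. Compound 3 is expected to give about 5000 nM, in the range 300 nM to 100000 nM, which would mean a step of a 20-fold lower number from compound 2 to compound 3 (1.30 log units; beyond the scatter).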

Compound 3, concentration for total growth inhibition: 400 nM
Compound 3: middle estimate off by 13-fold (1.10 log units), on the high side; low and high end bracket the measured number.
By their numbers in this assay, from the lowest: compounds 3 and 1 (each within the scatter of the next); then compound 2.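

In this assay, among these compounds, bromo in place of hydrogen on an aromatic carbon of the fused system gives a 250-fold lower number from compound 2 to compound 3 (2.40 log units; beyond the scatter) and is the first single change to be read, showing that this position can respond very strongly and that this one added heavy atom is enough to produce a large step. The chloro shared by compound 2 and compound 3 does not hold the value high once the bromo is present, and chloro in place of methoxy on an aromatic carbon gives a 1.2-fold lower number from compound 1 to compound 3 (0.08 log units; within the scatter), within the scatter, so with bromo on the fused ring these two groups cannot be told apart in this assay. No measurement shown here gives a reason for the size of the bromo step or for the lack of a readable chloro-methoxy difference.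

From the compounds shown here alone, it remains open whether bromo gives a step of similar size when methoxy rather than chloro is the other group, since the chloro-methoxy comparison is available only with bromo present. Going by these compounds, it is also open whether the step is particular to bromo or would also appear with another group on the same aromatic carbon, such as an amine, a carboxylic acid or a longer chain.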